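A few compounds are considered here, and "the series" means these few. Any claim that something is new, unique, unknown or untested is made for them only; others in the source may bear on it.

In a functional assay on HCT-116 cells (Homo sapiens) for inhibition, read by colorimetric assay, with a stated time of 3 days (on this read-out lower numbers stand for stronger inhibition and higher numbers for weaker inhibition), three compounds built on one shared core have been measured. Compound 1 `O=C(CCCCCCNC(=O)C(O)(O)C(F)(F)F)Nc1nccs1` gives 10800 nM, the second highest of the three numbers. Compound 3 `CCOc1ccc(-c2cnc(NC(=O)CCCCCCNC(=O)C(O)(O)C(F)(F)F)s2)cc1` gives 4050 nM, and compound 2 `O=C(CCCCCCNC(=O)C(O)(O)C(F)(F)F)Nc1nc(-c2ccccc2)c(-c2ccccc2)s1` gives 29900 nM. For the measured compounds named here, the only step between two compounds that differ in a single place is a 2.7-fold lower number from compound 1 to compound 3 (0.43 log units; beyond the scatter), where 4-ethoxyphenyl stands in place of hydrogen on an aromatic carbon. Compound 2 differs from compound 1 in more than one place, so its number can only be set beside that of compound 1 without a counted step.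

Compound 4 `COc1ccccc1NC(=O)CCCCCCNC(=O)C(O)(O)C(F)(F)F` has not yet been measured. Its difference from compound 1 is 2-methoxyphenyl in place of 1,3-thiazol-2-yl on an amide-type nitrogen. Going by the values given here, the whole five-membered aromatic ring with two hetero atoms leaves and a six-membered ring of carbon only enters, whereas the one measured step keeps that ring and merely adds a group on an aromatic carbon. Among the compounds with values here, no measured step therefore speaks directly to this change. Lacking such a guide, no movement beyond the scatter in this assay is expected in either direction, and the step expected is a 1.1-fold higher number from compound 1 to compound 4 (0.05 log units; within the scatter). Compound 4 is estimated at 12000 nM, with a range from 3000 nM to 50000 nM.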

Compound 4, half-maximal inhibitory concentration: 10100 nM
Beside the measured number, compound 4's estimate is 1.2-fold (0.07 log units) above it, within the range that was stated.
By their numbers in this assay, from the lowest: compound 3; then compounds 4 and 1 (each within the scatter of the next); then compound 2.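

In this assay, the whole ring on the amide-type nitrogen was exchanged, with 2-methoxyphenyl in place of 1,3-thiazol-2-yl, and the result is a 1.1-fold lower number from compound 1 to compound 4 (0.03 log units; within the scatter). For the compounds shown here, this is the first reading of the ring itself, as the earlier single-place step kept that ring and only added a group to it; here, a six-membered ring of carbon only, carrying a methoxy group, gives a number that cannot be told apart from that of the five-membered ring with its nitrogen and sulfur, so in this one pair the ring's hetero atoms are not required to hold this level of inhibition. No measurement of any property of these two groups accompanies this result.

A plain phenyl or a 4-methoxyphenyl group on the same nitrogen would show whether the methoxy group, and where it sits, counts for anything at all. Going by these compounds, it also remains open whether any ring is needed on this nitrogen, which a simple butyl chain there would test, and whether a 4-ethoxyphenyl group added to the carbon-only ring would lower the number as it did on the five-membered ring.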